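From a Diethylamino Group to Bare Hydrogen

The source may report more compounds than this note shows. Statements on the series, on what has been measured and on what is new or still open speak of the compounds shown alone.

The compounds share one core and differ only in the group on the aniline ring. Compound 1 `COc1cccc(Nc2nccc(-c3cc(C)oc3C)n2)c1` gives 5800 nM in a functional assay for inhibition, with Homo sapiens as the target; a lower number here means a stronger inhibitor, a higher number a weaker inhibitor. Compound 2 `CCc1ccc(Nc2nccc(-c3cc(C)oc3C)n2)cc1` gives 19200 nM in this assay. Compound 3 `CCN(CC)c1ccc(Nc2nccc(-c3cc(C)oc3C)n2)cc1` reaches only a limit in this assay, > 24000 nM. Compound 3 therefore stands at the limit of > 24000 nM in this assay, at which 1 of the 3 values shown sits, and its true position beyond that point is not known.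

The change to compound 4 `Cc1cc(-c2ccnc(Nc3ccccc3)n2)c(C)o1` is hydrogen in place of diethylamino on an aromatic carbon. Among the compounds with values here, the only measured step that bears on it is an at least 1.2-fold higher number from compound 2 to compound 3 (0.09 log units; that floor lies within the scatter), a floor that lies within the scatter and so reveals no clear effect of the group on that aromatic carbon. Since compound 3 is known only as a limit, the size of any step from it can be stated only loosely.

Compound 4 is expected to fall near the values of compounds 1 and 2. Compound 4 is estimated at 10000 nM in this assay, with a range from 3000 nM to 30000 nM. The expected step of an at least 2.4-fold lower number from compound 3 to compound 4 (0.38 log units; beyond the scatter) would thus point toward a lower number.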

Compound 4, half-maximal inhibitory concentration: 2000 nM
Compound 4: middle estimate off by 5.0-fold (0.70 log units), on the high side; measured number below the stated range.
By their numbers in this assay, from the lowest: compound 4; then compound 1; then compound 2. At a limit, above all of these: compound 3.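

Compound 4 shows that the bare aromatic carbon, not any of the groups tried so far, gives the strongest inhibitor of the four in this assay. The earlier compounds shown here revealed no clear effect of the group here, yet hydrogen now brings a 9.6-fold lower number from compound 2 to compound 4 (0.98 log units; beyond the scatter) in place of ethyl and a 2.9-fold lower number from compound 1 to compound 4 (0.46 log units; beyond the scatter) in place of methoxy. In place of diethylamino, an at least 12-fold lower number from compound 3 to compound 4 (1.07 log units; beyond the scatter) is only a floor, since compound 3 is known only as a limit: the limit of > 24000 nM in this assay, at which 1 of the 4 values shown sits.

The compounds shown leave open whether any group on this aromatic carbon can keep the number as low as hydrogen does, for instance a fluorine, a hydroxyl or a methyl. They also leave open where compound 3 truly stands beyond its limit, and so how large the step from diethylamino really is.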